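This account rests on a few compounds, and the source may have more. Where it says the series, first, only, none or still open, it means among the compounds named here.

Measured so far in a functional assay on CHO cells (Cricetulus griseus) for inhibition, read by MTT assay, with a stated time of 96 h; a lower number here means a stronger inhibitor, a higher number a weaker inhibitor:
- compound 1 `C=C(C)[C@@H](OC(=O)c1ccc(F)c2ccccc12)C(N)=O`: > 100000 nM
- compound 2 `C=C(C)[C@@H](OC(=O)c1ccc(OC)c2ccc(OC)cc12)C(N)=O`: > 100000 nM

Compound 2 stands at > 100000 nM in this assay, which is a limit of the assay and not a number. Compound 1 gives > 100000 nM, and this too is a limit. For the measured compounds named here, the series so far therefore comes down to the limit of > 100000 nM in this assay, at which 2 of the 2 values shown sit. Going by the values given here, neither compound has a numerical half-maximal inhibitory concentration, and no measured step is available.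

Compound 3 `COc1ccc2c(OC)ccc(C(=O)O[C@H](C(N)=O)C3(C)CO3)c2c1` keeps the core of compound 2. The change is carbamoyl(2-methyloxiran-2-yl)methyl in place of 1-carbamoyl-2-methylprop-2-en-1-yl on an oxygen next to a carbonyl group. One three-membered non-aromatic ring with 1 hetero atom enters with the carbamoyl(2-methyloxiran-2-yl)methyl group.

Because compound 2 sits at the limit > 100000 nM, the only direction open to a measurable change in this assay is towards stronger inhibition. A result at the same limit also remains possible. The estimated change is an at least 5.0-fold lower number from compound 2 to compound 3 (0.69 log units; beyond the scatter), and its size is only loosely fixed. For compound 3 the expected value is 20000 nM, with an expected range of 3000 nM to 100000 nM.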

Compound 3, half-maximal inhibitory concentration: 6000 nM
The estimate for compound 3 lay 3.3-fold (0.52 log units) above the measured number; the measured number falls inside the stated range.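

In this assay, carbamoyl(2-methyloxiran-2-yl)methyl in place of 1-carbamoyl-2-methylprop-2-en-1-yl on an oxygen next to a carbonyl group gives an at least 16-fold lower number from compound 2 to compound 3 (1.22 log units; beyond the scatter), so a change at this position alone, with the core of compound 2 kept, can bring the read-out off the limit. The exchange brings in one three-membered non-aromatic ring with 1 hetero atom and removes one double bond outside aromatic rings, and the step does not separate these two features from each other. Compound 2 remains a limit of the assay and not a number, so the step fixes only a minimum size, and most of the series still rests at that limit: the limit of > 100000 nM in this assay, at which 2 of the 3 values shown sit.

The compounds shown leave open whether the oxygen of the three-membered ring is needed, which a cyclopropyl group or an open-chain diol at the same place would test. They also leave open whether the same exchange on the core of compound 1, which carries a fluorine, or a replacement of the primary amide by a carboxylic acid, would keep a measurable number.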